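The source may report more compounds than this note shows. Statements on the series, on what has been measured and on what is new or still open speak of the compounds shown alone.

Compound 1 `O=S(=O)(c1cc(F)cc(F)c1)c1cnc2cc(F)ccc2c1-c1ccc(Cl)cc1`: 0.03 mL/min in an ADME assay on microsomes from liver (Homo sapiens) for metabolic stability, tested at 2.5 uM; on this read-out lower numbers stand for slow clearance and higher numbers for fast clearance.
Compound 2 `O=S(=O)(c1ccc(F)c(F)c1)c1cnc2cc(F)ccc2c1-c1ccc(Cl)cc1`: 0.01 mL/min in this assay.
Compound 3 `O=S(=O)(c1cc(F)cc(F)c1)c1cnc2cc(F)ccc2c1-c1cccc(Cl)c1`: 0.22 mL/min in this assay.

These three share one core, and each carries a sulfonyl sulfur bearing a difluorophenyl group. Compound 2 differs from compound 1 by 3,4-difluorophenyl in place of 3,5-difluorophenyl on a sulfonyl sulfur, a change that gave a 3.0-fold lower number from compound 1 to compound 2 (0.48 log units; beyond the scatter). Compound 3 differs from compound 1 by 3-chlorophenyl in place of 4-chlorophenyl on an aromatic carbon, which gave a 7.3-fold higher number from compound 1 to compound 3 (0.87 log units; beyond the scatter), leaving compound 3 with the highest number of the three.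

Compound 4 `O=S(=O)(c1ccc(F)c(F)c1)c1cnc2cc(F)ccc2c1-c1cccc(Cl)c1` is not yet measured in this assay. It differs from compound 3 by 3,4-difluorophenyl in place of 3,5-difluorophenyl on a sulfonyl sulfur, the same change as that from compound 1 to compound 2, made on the same place. Resting on that earlier step, a 3.0-fold lower number from compound 1 to compound 2 (0.48 log units; beyond the scatter), compound 4 is expected to show a 3.1-fold lower number from compound 3 to compound 4 (0.50 log units; beyond the scatter). Compound 4 is thus estimated at 0.07 mL/min in this assay, with a range from 0.03 mL/min to 0.18 mL/min expected.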

Compound 4, intrinsic clearance in a liver preparation (reported as CLH), per the amount of preparation that the assay uses: 0.38 mL/min
The estimate for compound 4 lay 5.4-fold (0.73 log units) below the measured number; measured number outside the range, above it.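

In this assay, 3,4-difluorophenyl in place of 3,5-difluorophenyl on a sulfonyl sulfur gave a 1.7-fold higher number from compound 3 to compound 4 (0.24 log units; within the scatter), so the step seen on the core of compound 1 did not carry over unchanged: the same change on two cores in this assay, a 3.0-fold lower number (0.48 log units; beyond the scatter) from compound 1 to compound 2 and a 1.7-fold higher number (0.24 log units; within the scatter) from compound 3 to compound 4, 5.2-fold (0.71 log units) apart, beyond the scatter of two such steps. Read the other way, 3-chlorophenyl in place of 4-chlorophenyl gave a 38-fold higher number from compound 2 to compound 4 (1.58 log units; beyond the scatter), and this step also depended on its partner group: the same change on two cores in this assay, a 7.3-fold higher number (0.87 log units; beyond the scatter) from compound 1 to compound 3 and a 38-fold higher number (1.58 log units; beyond the scatter) from compound 2 to compound 4, 5.2-fold (0.71 log units) apart, beyond the scatter of two such steps. These four compounds form a single set of two changes, so they show that the two changes do not simply add here, but not why, nor how either change would behave on a further core.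

From the compounds shown here alone, it remains open whether the same holds with a plain phenyl or a pyridine on the sulfonyl sulfur. A methoxy group in place of the chlorine is also left untested by the compounds shown here.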